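A few compounds are considered here, and "the series" means these few. Any claim that something is new, unique, unknown or untested is made for them only; others in the source may bear on it.

Compound 2 `COc1cc(-c2cc(/C=C/C(=O)c3ccc(N)cc3)[nH]n2)cc(OC)c1OC` and compound 1 `COc1ccc(-c2cc(/C=C/C(=O)c3ccc(N)cc3)[nH]n2)cc1` have both been measured in a functional assay on SK-MEL-28 cells (Homo sapiens) for inhibition, read by sulforhodamine B assay, with a stated time of 48 h; a lower number here means that less compound is tolerated, a higher number that more compound is tolerated. In this assay compound 2 gives 8930 nM, and compound 1 gives 8570 nM. Of the two numbers shown, compound 2 is nominally the one on top, but its gap to compound 1 lies within the scatter, so the two cannot be told apart on this evidence. Among the compounds with values here, no step between measured compounds that differ in a single place is available. Compound 3 `COc1ccc(-c2cc(/C=C/C(=O)c3ccc(N)cc3)[nH]n2)cc1OC` is the next member of the series and differs from compound 2 in one place: hydrogen in place of methoxy on an aromatic carbon. Compound 1 and compound 2 differ only in how many methoxy groups that aromatic ring carries, and their values sit together, which gives no sign that adding or removing a methoxy group on this ring moves the number. Compound 3 is therefore expected to land close to compound 2, with a step of a 1.0-fold lower number from compound 2 to compound 3 (0.01 log units; within the scatter) that stays within the scatter. For compound 3 the estimate in this assay is 8700 nM, with a plausible range from 4500 nM to 17000 nM.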

Compound 3, concentration lethal to 50% of the cells: 21100 nM
Compound 3: the middle estimate sits 2.4-fold (0.38 log units) below what was measured, outside the stated range (above it).
By their numbers in this assay, from the lowest: compounds 1 and 2 (each within the scatter of the next); then compound 3.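

In this assay hydrogen in place of methoxy on an aromatic carbon, ortho to a methoxy group and meta to a large group, brings a 2.4-fold higher number from compound 2 to compound 3 (0.37 log units; beyond the scatter) and so shows that this position is not indifferent to the change. Methoxy in place of hydrogen on an aromatic carbon brings a 2.5-fold higher number from compound 1 to compound 3 (0.39 log units; beyond the scatter) as well, so the number rises both in the step that takes a methoxy group away and in the step that adds one, and among these three compounds the count of methoxy groups on the ring does not by itself set the order of the values. Nothing measured here gives a reason for either step.

On these data alone, it remains open whether another group at this position, such as a hydroxyl, a fluorine or an amine, would move the number in the same way as hydrogen does. As far as these compounds go, it also remains open whether an ethoxy group would behave like methoxy here, and how a ring carrying no methoxy group at all would stand against these three compounds.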